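Methylsulfanyl for Methoxycarbonyl on a Saturated Chain Carbon

The source may hold more compounds than are shown below. What is called first, only, known or untested is meant among the compounds shown, and "the series" means these compounds.

Two related compounds set the scene: compound 1 (`CCOC(=O)/C(=C\c1cccc(OCC(=O)O)c1OC)c1nc(-c2ccccc2)c(-c2ccccc2)o1`) and compound 2 (`COC(=O)C(Cc1cccc(OCC(=O)O)c1)c1nc(-c2ccccc2)c(-c2ccccc2)o1`). In a functional assay for inhibition, with Homo sapiens as the target (on this read-out lower numbers stand for stronger inhibition and higher numbers for weaker inhibition), compound 2 gives 80 nM and compound 1 gives 130 nM and these two numbers lie within the usual scatter of each other, so neither can be ranked above the other.

Compound 3 (`CSC(Cc1cccc(OCC(=O)O)c1)c1nc(-c2ccccc2)c(-c2ccccc2)o1`) is compound 2 with a single change: methylsulfanyl in place of methoxycarbonyl on a saturated chain carbon bound to an aromatic carbon and a saturated chain carbon. For the measured compounds named here, no measured pair shows this swap on its own, so any forecast in this assay rests on thin support. Going by the values given here, the only guide is that compound 2 at 80 nM and compound 1 at 130 nM stay close although their structures differ in more than one place. The expected move is therefore small and toward weaker inhibition, estimated as a 2.0-fold higher number from compound 2 to compound 3 (0.30 log units; within the scatter) and lying near the edge of the usual scatter. Compound 3 is estimated at 160 nM (expected range 40 nM to 600 nM).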

Compound 3, half-maximal inhibitory concentration: 1300 nM
Compound 3: the middle estimate sits 8.1-fold (0.91 log units) below what was measured; the measured number lies above the stated range.
By their numbers in this assay, from the lowest: compounds 2 and 1 (each within the scatter of the next); then compound 3.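

In this assay, putting methylsulfanyl in place of methoxycarbonyl on a saturated chain carbon bound to an aromatic carbon and a saturated chain carbon brings a 16-fold higher number from compound 2 to compound 3 (1.21 log units; beyond the scatter), a large step well beyond the scatter, so the group at this carbon clearly matters for inhibition. Compounds 1 and 2 could not show this, since they differ in more than one place and their closeness says nothing about this group on its own. The swap removes methoxycarbonyl, with its 4 heavy atoms, double bond and 2 hydrogen-bond acceptors, and brings in methylsulfanyl, with 2 heavy atoms and 1 hydrogen-bond acceptor, but no measurement shown here tells which of these differences accounts for the step.

As far as these compounds go, it remains open whether the weaker inhibition comes from losing methoxycarbonyl or from adding methylsulfanyl, a question that other groups on the same carbon, such as a carboxylic acid, an amide or a methoxy group, could help to separate. From the compounds shown here alone, this is also a single step on a single compound, so it remains unknown whether the same swap would have a similar effect on the core of compound 1.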